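The source may hold more compounds than are shown below. What is called first, only, known or untested is meant among the compounds shown, and "the series" means these compounds.

Working notes on the series

Of the compounds shown here, two have numbers so far. Compound 1 `N=C(N)c1ccc(-c2ccc(-c3cncc4ccccc34)s2)s1` gives, in a functional assay on UACC-257 cells (Homo sapiens) for inhibition, read by sulforhodamine B assay, with a stated time of 48 h (a lower number here means a stronger inhibitor of growth, a higher number a weaker inhibitor of growth), a value of 2470 nM. Compound 2 `N=C(N)c1ccc(-c2ccc(-c3ccc(F)cc3)o2)o1` gives in this assay a value of 1980 nM. The two numbers lie within the scatter of each other, so nothing separates compound 2 from compound 1 on these data; compound 2 simply sits where compound 1 sits, with one partner only.

The next compound is compound 3 `N=C(N)c1ccc(-c2ccc(-c3ccc(Cl)cc3)o2)o1`. It differs from compound 2 in one place: chloro in place of fluoro on an aromatic carbon. Among the compounds with values here, no pair that differs in one place has been measured, so there is no step in hand on which to base the size of this change. The expectation rests on the change alone. A swap of one halogen for another halogen at the same aromatic carbon, with no change in ring count, donors, acceptors or charge, is expected to move this assay by no more than the scatter, in either direction; the step from compound 2 to compound 3 is estimated at a 1.2-fold lower number from compound 2 to compound 3 (0.07 log units; within the scatter). Compound 3 is therefore estimated at 1700 nM in this assay, within a range from 700 nM to 4200 nM.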

Compound 3, concentration for 50% growth inhibition: 1990 nM
For compound 3 the middle estimate is 1.2-fold (0.07 log units) below the measured one; low and high end bracket the measured number.
By their numbers in this assay, from the lowest: compounds 2, 3 and 1 (each within the scatter of the next).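

In this assay, within the data shown here, the series now has its one readable step, a 1.0-fold higher number from compound 2 to compound 3 (0.00 log units; within the scatter), for chloro in place of fluoro on an aromatic carbon of a six-membered aromatic ring of carbon only, para to a large group. The earlier compounds shown here could not isolate any single position, because compound 1 and compound 2 differ in more than one place; this pair shows that, at this one position, the two halogens cannot be told apart on this read-out. No measured property of either compound bears on this result, so the data offer no explanation for it.

Going by these compounds, it remains open whether a group other than a halogen at this position, such as an amine, a carboxylic acid, a methoxy group or a longer chain, would give a step beyond the scatter from compound 2. On these data alone, it is also open whether the same swap of halogens would read the same way on another core, such as that of compound 1, since this single pair cannot establish a pattern beyond compound 2 and compound 3.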